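The source may report more compounds than this note shows. Statements on the series, on what has been measured and on what is new or still open speak of the compounds shown alone.

In an assay on isolated protein for inhibition of tyrosine-protein kinase Mer (Homo sapiens), read by LC-MS (a lower number here means a stronger inhibitor, a higher number a weaker inhibitor), compound 1, `CN(Cc1ccc2nccn2c1)c1nnc(-c2ccc(-c3ccccc3)cc2)o1`, gives 39.8 nM. Compound 2, `Cc1nn(C)c(C)c1-c1ccc(-c2nnc(N(C)Cc3ccc4nccn4c3)o2)c(F)c1`, gives 12.6 nM in this assay, which is the lowest of the two numbers shown; its nearest neighbour, compound 1, gives a number that is beyond the scatter of repeated measurements above it, so on these two values compound 2 stands as the stronger inhibitor. Compound 3, `Cc1nn(C)c(C)c1-c1ccc(-c2nnc(N(C)Cc3ccc4nccn4c3)o2)c(C#N)c1`, has not yet been measured. It differs from compound 2 in one place: cyano in place of fluoro on an aromatic carbon, the new group sitting on an aromatic carbon of a six-membered aromatic ring of carbon only, ortho to a large group and meta to the 1,3,5-trimethyl-1H-pyrazol-4-yl group. Among the compounds with values here, no pair of measured compounds shows this exchange, so no measured step guides it. The step from compound 2 to compound 3 is expected to be a 1.1-fold higher number from compound 2 to compound 3 (0.05 log units; within the scatter), that is, none beyond the scatter. Compound 3 is therefore estimated at 14 nM in this assay, within a range from 5 nM to 40 nM.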

Compound 3, half-maximal inhibitory concentration in the tyrosine-protein kinase Mer assay: 100000 nM
Compound 3: middle estimate off by 7100-fold (3.85 log units), on the low side, outside the stated range (above it).
By their numbers in the tyrosine-protein kinase Mer assay, from the lowest: compound 2; then compound 1; then compound 3.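

In the tyrosine-protein kinase Mer assay, the exchange on the aromatic carbon ortho to a large group and meta to the 1,3,5-trimethyl-1H-pyrazol-4-yl group, from fluoro in compound 2 (12.6 nM) to cyano in compound 3 (100000 nM), gives a 7900-fold higher number from compound 2 to compound 3 (3.90 log units; beyond the scatter), so at this position the choice between fluoro and cyano decides between a strong inhibitor and a very weak one, which compound 1 and compound 2 alone could not show. In a physicochemical assay for lipophilicity, at pH 7.4 (a higher number here means a more lipophilic compound, a lower number a more polar compound), the same exchange, from compound 2 (3.2) to compound 3 (2.9), gives a number 0.30 log units lower from compound 2 to compound 3 (within the scatter), so the large loss of inhibition has no counterpart beyond the scatter in that measure. Nothing shown here accounts for the loss.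

On these data alone, it remains open whether the loss is peculiar to cyano or would also follow from a chlorine, a methyl or a methoxy group on this carbon. As far as these compounds go, it also remains open whether an amine or a longer chain there would be accepted.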